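Swapping Piperidin-1-yl for 2-Fluorophenyl on the Carbonyl

This account rests on a few compounds, and the source may have more. Where it says the series, first, only, none or still open, it means among the compounds named here.

Compound 1, `O=C(N1CCCCC1)N1CC(c2nc(-c3cccc(Cl)c3)no2)C1`: > 10000 nM
Compound 2, `Cc1cccc(-c2noc(C3CN(C(=O)C4CCC(C(F)(F)F)CC4)C3)n2)c1`: > 10000 nM
Compound 3, `Cc1ccc(C(=O)N2CC(c3nc(-c4cccc(F)c4)no3)C2)cc1`: > 10000 nM

In an assay on HEK293 cells for negative allosteric modulation of metabotropic glutamate receptor 5 (Homo sapiens), read by FLIPR (on this read-out lower numbers stand for stronger inhibition and higher numbers for weaker inhibition), compound 1 gives only a limit, > 10000 nM, so its true inhibition is not pinned down. Compound 2 likewise returns only a limit, > 10000 nM. Compound 3 also stops at a limit, > 10000 nM. All three share (the limit of > 10000 nM in this assay, at which 3 of the 3 values shown sit), so no ordering among them can be read from these numbers.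

Compound 4, `O=C(c1ccccc1F)N1CC(c2nc(-c3cccc(Cl)c3)no2)C1`, differs from compound 1 by 2-fluorophenyl in place of piperidin-1-yl on a carbonyl carbon. For the measured compounds named here, with no measured step among the compounds, the only guide is that every value so far sits at the limit. The expected step is a number no higher from compound 1 to compound 4 (the limit leaves the size open), nothing beyond the scatter. Compound 4 is therefore estimated at 10000 nM, between 2500 nM and 30000 nM, most likely reported again as a limit.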

Compound 4, half-maximal inhibitory concentration: 670 nM
Estimate against measurement, compound 4: 15-fold (1.17 log units) above; the measured number lies below the stated range.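

Putting 2-fluorophenyl in place of piperidin-1-yl on the carbonyl carbon gives an at least 14-fold lower number from compound 1 to compound 4 (1.17 log units; beyond the scatter) in this assay. This shows that the group on this carbonyl can decide whether the shared core gives a measurable inhibition at all. The true size of the step remains unknown, because its starting point is only a limit: the limit of > 10000 nM in this assay, at which 3 of the 4 values shown sit.

The compounds shown leave open whether the fluorine or the aromatic ring itself accounts for the change. They also leave open how an unsubstituted phenyl or a pyridin-2-yl group would fare on the same carbonyl.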